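A Second Chloro Added Where Stability Is Untested

The source may hold more compounds than are shown below. What is called first, only, known or untested is meant among the compounds shown, and "the series" means these compounds.

Compound 1 `CCCCCCCCCCNC(=O)Oc1ccc(Cl)cc1C(=O)Nc1cccc(Cl)c1` and compound 2 `CCCCCCCCCCCNC(=O)Oc1ccc(Cl)cc1C(=O)Nc1cccc(Cl)c1` share one core and differ only in the length of the saturated chain. In an ADME assay for metabolic stability, read by HPLC, at pH 7.4 (on this read-out lower numbers stand for a shorter-lived compound and higher numbers for a longer-lived compound), compound 1 gives 43 h, and compound 2 gives 43 h. Among the compounds with values here, the step of no change at the digits printed from compound 1 to compound 2 (within the scatter) lies within the scatter, so compound 2 stands level with compound 1 on the numbers so far.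

Compound 3 `CCCCCCCCCCCNC(=O)Oc1ccc(Cl)cc1C(=O)Nc1ccc(Cl)c(Cl)c1` differs from compound 2 by chloro in place of hydrogen on an aromatic carbon. Within the data shown here, no measured pair shows this kind of difference; the only measured step concerns the chain, not the aromatic ring, and its size, which was within the scatter, gives no direction for the present change. With nothing in the data pointing up or down, the step from compound 2 to compound 3 in this assay is expected to be no change at the digits printed from compound 2 to compound 3 (within the scatter), that is, no change beyond the scatter. Compound 3 is therefore estimated at 43 h in this assay, with a range from 18 h to 100 h to allow for the untested change.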

Compound 3, half-life: 43 h
Estimate against measurement, compound 3: no gap at the digits printed, and the stated range covers the measured number.
By their numbers in this assay, from the lowest: compounds 1, 2 and 3 (each within the scatter of the next).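

Chloro in place of hydrogen on an aromatic carbon, ortho to a chloro group and para to a large group, turns 3-chlorophenyl into 3,4-dichlorophenyl and gives no change at the digits printed from compound 2 to compound 3 (within the scatter) in this assay. Within the data shown here, the earlier compounds spoke only to the saturated chain, so this is the first reading from the aromatic ring, and it shows that the half-life can hold level with this ring carrying a second chloro, at least on the chain of compound 2. The information at hand offers no explanation for this result.

As far as these compounds go, it remains open whether another group at this same place, such as fluoro, methoxy, an amine or a carboxylic acid, would also stay within the scatter in this assay, or would move the half-life in either direction. Also open is whether this chloro would read the same on the chain of compound 1, or on a much shorter chain, as the single pair shown rests on one chain only.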